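Methyl on the amine nitrogen, carried over to a second core

The source may report more compounds than this note shows. Statements on the series, on what has been measured and on what is new or still open speak of the compounds shown alone.

Compound 3 `COc1ccc(C(=O)c2cc(OC)c(OC)c(OC)c2)c(NC(=O)CN)c1` and compound 1 `CNCC(=O)Nc1cc(OC)ccc1C(=O)c1cc(OC)c(OC)c(OC)c1` share one core; compound 2 `C=C(c1cc(OC)c(OC)c(OC)c1)c1ccc(OC)cc1NC(=O)CN` is built on a second core, and the difference between the two cores is not broken down here. In a functional assay on HCT-8 cells (Homo sapiens) for antiproliferative activity, read by MTT assay, with a stated time of 48 h (on this read-out lower numbers stand for stronger inhibition and higher numbers for weaker inhibition), compound 3 gives 330 nM, compound 1 gives 780 nM and compound 2 gives 60 nM, the lowest of the three numbers. The change methyl in place of hydrogen on an amine nitrogen produced a 2.4-fold higher number from compound 3 to compound 1 (0.37 log units; beyond the scatter). Compound 4 `C=C(c1cc(OC)c(OC)c(OC)c1)c1ccc(OC)cc1NC(=O)CNC` carries the same change on the core of compound 2, namely (methyl in place of hydrogen on an amine nitrogen), at a place described in identical words. Because the same change gave a 2.4-fold higher number from compound 3 to compound 1 (0.37 log units; beyond the scatter), the expected step in this assay is a 2.4-fold higher number from compound 2 to compound 4 (0.38 log units; beyond the scatter). Compound 4 is therefore estimated at 145 nM, with a likely span from 65 nM to 350 nM; a single precedent supports this expectation.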

Compound 4, half-maximal inhibitory concentration: 190 nM
Compound 4: middle estimate off by 1.3-fold (0.12 log units), on the low side, within the range that was stated.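

Within this assay methyl in place of hydrogen on an amine nitrogen gives a 3.2-fold higher number from compound 2 to compound 4 (0.50 log units; beyond the scatter) and so moves the number the same way on both cores. The two steps agree in direction and size: the same change on two cores in this assay, a 2.4-fold higher number (0.37 log units; beyond the scatter) from compound 3 to compound 1 and a 3.2-fold higher number (0.50 log units; beyond the scatter) from compound 2 to compound 4, 1.3-fold (0.13 log units) apart, within the scatter of two such steps. This shows that the change carried over between these two cores in this one cell assay, but two pairs do not show that it would carry to any further core or to any other read-out.

Still open, from the compounds shown here alone, is whether ethyl, or a second methyl on the same amine nitrogen, would extend the step. Also open, going by these compounds, is how a longer chain in place of the aminomethyl would behave on either core.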